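The source may hold more compounds than are shown below. What is called first, only, known or untested is meant among the compounds shown, and "the series" means these compounds.

Four compounds share one core and differ only in the aromatic group attached to it. Compound 1 `COc1nc(-c2cccc(Cl)c2)ccc1[C@@H](c1ccccc1)[C@@](O)(CCN(C)C)c1cccc2ccccc12` and compound 2 `COc1nc(-c2ccccc2F)ccc1[C@@H](c1ccccc1)[C@@](O)(CCN(C)C)c1cccc2ccccc12` were tested in a toxicity assay on HeLa cells (Homo sapiens) for cytotoxicity (a higher number here means that more compound is tolerated, a lower number that less compound is tolerated), but neither gave a number. In this assay compound 1 shows "nd" (no result reported). In this assay compound 2 shows "nd" (no result reported), so compound 2 has no result of its own to stand on, and compound 1 is in the same position. Among the measured compounds shown here, the only number comes from compound 3 `COc1nc(-c2ccncc2)ccc1[C@@H](c1ccccc1)[C@@](O)(CCN(C)C)c1cccc2ccccc12`, which in this assay gives 9.6 ug/mL. Compound 4 `COc1nc(-c2cnsc2)ccc1[C@@H](c1ccccc1)[C@@](O)(CCN(C)C)c1cccc2ccccc12` has not yet been measured. It differs from compound 2 in one place: 1,2-thiazol-4-yl in place of 2-fluorophenyl on an aromatic carbon. No measured pair among these compounds differs in just one place, so there is no measured step to lean on, and the direction of the change in this assay from compound 2 to compound 4 cannot be read from the data. Compound 3 is the nearest measured relative. Resting on compound 3 with 9.6 ug/mL, compound 4 is expected to give an estimated 10 ug/mL, with a range from 4 ug/mL to 25 ug/mL.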

Compound 4, half-maximal cytotoxic concentration: 28.8 ug/mL
Estimate against measurement, compound 4: 2.9-fold (0.46 log units) below, and the stated range ends below it.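

In this assay, placing 1,2-thiazol-4-yl where compound 3 carries pyridin-4-yl gives a 3.0-fold higher number from compound 3 to compound 4 (0.48 log units; beyond the scatter). Among the compounds shown here, this is the first measured comparison at this position, and it shows that exchanging one aromatic ring containing nitrogen for another can change how much compound the cells tolerate, with all else in the molecule held the same. No measurement shown here explains the difference between these two rings.

Going by these compounds, compound 1 and compound 2 have no numbers, so the steps from them to the other compounds cannot be read, and it remains unknown how rings of carbon only, such as 2-fluorophenyl, compare with pyridin-4-yl or 1,2-thiazol-4-yl. On these data alone, it is also open how a non-aromatic group at this position, such as a morpholine ring or a carboxylic acid, would behave in this assay.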